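The compounds below may be only part of what the source reports. "The series", "measured", "known", "first", "only" and "open" are said of these compounds alone.

Measured so far in a functional assay on HMEC-1 cells (Homo sapiens) for antiproliferative activity, read by cell counting, with a stated time of 4 days; on this read-out lower numbers stand for stronger inhibition and higher numbers for weaker inhibition:
- compound 1 `COc1ccc(Oc2ccccc2NC(C)=C2C(=O)CC(c3ccccc3)CC2=O)cc1OC`: 140 nM
- compound 2 `CC(Nc1ccccc1Oc1ccc(C(C)O)cc1)=C1C(=O)CC(c2ccccc2)CC1=O`: 140 nM

The two compounds stand level, with compound 2 at 140 nM. The next compound, compound 3 `CCOc1ccccc1NC(C)=C1C(=O)CC(c2ccccc2)CC1=O`, differs from compound 2 as follows: ethyl in place of 4-(1-hydroxyethyl)phenyl on an oxygen on an aromatic ring. In words, it carries ethyl in place of 4-(1-hydroxyethyl)phenyl on an oxygen on an aromatic ring. Going by the values given here, only one measured step bears on this change, no change at the digits printed from compound 1 to compound 2 (within the scatter). That step replaced one ring-bearing group on the same oxygen with another, whereas ethyl has no ring, so it offers only limited guidance here. Among the compounds with values here, the data include no compound with a small chain at this place. A moderate loss of activity is therefore expected, with wide uncertainty, and the expected change is a 2.1-fold higher number from compound 2 to compound 3 (0.33 log units; beyond the scatter). For compound 3 the estimated value is 300 nM, with an expected range of 90 nM to 1000 nM.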

Compound 3, half-maximal inhibitory concentration: 100 nM
Beside the measured number, compound 3's estimate is 3.0-fold (0.48 log units) above it, and the stated range covers the measured number.
By their numbers in this assay, from the lowest: compounds 3, 1 and 2 (each within the scatter of the next).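

In this assay, ethyl in place of 4-(1-hydroxyethyl)phenyl gives a 1.4-fold lower number from compound 2 to compound 3 (0.15 log units; within the scatter), and ethyl in place of 3,4-dimethoxyphenyl gives a 1.4-fold lower number from compound 1 to compound 3 (0.15 log units; within the scatter). The earlier step had only exchanged one ring-bearing group for another on this oxygen, whereas compound 3 has no ring there and still stands level with both, so among these compounds an aromatic ring on the oxygen is not needed to hold this level of activity. No measured evidence here accounts for why these very different groups read alike.

From the compounds shown here alone, whether that tolerance extends to a methyl group, a longer chain such as butyl, or a chain ending in an amine or a carboxylic acid stays open. So does the effect of leaving the oxygen with a bare hydrogen.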